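Replacing phenyl with thiophen-2-yl in compound 2

This account rests on a few compounds, and the source may have more. Where it says the series, first, only, none or still open, it means among the compounds named here.

Of the compounds shown here, two have numbers so far in an ADME assay on HEK-293T cells (Homo sapiens) for inhibition, read by CCK-8 assay, with a stated time of 48 h, tested at 20 uM (a higher number here means more inhibition of growth at the concentration tested, a lower number less inhibition of growth), and they lie clearly apart. Compound 1 `N#C/C(=C\c1ccccc1OS(=O)(=O)c1ccc([N+](=O)[O-])cc1)C(=O)Nc1nnc(-c2cccs2)s1` gives 33% there and compound 2 `Cc1ccc(S(=O)(=O)Oc2cccc(/C=C(\C#N)C(=O)Nc3nnc(-c4ccccc4)s3)c2)cc1` gives 52% there, which makes compound 2 the higher of the two by a gap beyond the usual scatter. The next compound to be measured is compound 3 `Cc1ccc(S(=O)(=O)Oc2cccc(/C=C(\C#N)C(=O)Nc3nnc(-c4cccs4)s3)c2)cc1` and it has thiophen-2-yl in place of phenyl on an aromatic carbon with the rest of compound 2 unchanged. Among the compounds with values here, no measured pair shows this swap alone, so the forecast rests on little. Within the data shown here, compound 1 at 33% is the only other reading and gives a weak hint toward a lower number. The expected change a number 6 percentage points lower from compound 2 to compound 3 (within the scatter) is small and downward and is estimated to stay within the usual scatter. For compound 3 the estimated value is 46% in this assay with an expected range from 28% to 64% at this stage.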

Compound 3, percent growth inhibition at one concentration: 43%
Compound 3: the middle estimate sits 3 percentage points above what was measured, and the stated range covers the measured number.
By their numbers in this assay, from the lowest: compounds 1, 3 and 2 (each within the scatter of the next, the first and the last beyond it).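

In this assay, within the data shown here, putting thiophen-2-yl in place of phenyl gives a number 9 percentage points lower from compound 2 to compound 3 (within the scatter), and this is the first reading of that swap on its own. On this aromatic carbon of the five-membered ring, then, this assay does not separate the six-membered carbon ring from the five-membered ring with one hetero atom, at least for this pair. Nothing available gives a measured property that would bear on this step.

From the compounds shown here alone, it remains open how the read-out would respond at this position to a group of a different kind, such as a primary amine, a carboxylic acid or a short alkyl chain. Going by these compounds, it is also open whether the same swap would read alike with the rest of the molecule changed.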